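Swapping a Benzothiazole Amide for an Ethylthiadiazole

This account rests on a few compounds, and the source may have more. Where it says the series, first, only, none or still open, it means among the compounds named here.

Four amides that share one pyrrole-bearing core make up this set. Compound 1 `O=C(Cn1c(-c2ccc3ccccc3c2)cc(-c2ccccc2)c1-c1ccco1)Nc1nc2ccccc2s1` carries a 1,3-benzothiazol-2-yl group on the amide nitrogen, and in an ADME assay on HEK-293T cells (Homo sapiens) for cytotoxicity, read by MTT assay, with a stated time of 72 h (a lower number here means a stronger inhibitor, a higher number a weaker inhibitor), compound 1 gives < 50000 nM, which is a limit of the assay and not a number. Compound 2 `CCc1nnc(NC(=O)Cn2c(-c3ccc4ccccc4c3)cc(-c3ccccc3)c2-c2ccco2)s1` differs from compound 1 by 5-ethyl-1,3,4-thiadiazol-2-yl in place of 1,3-benzothiazol-2-yl on an amide-type nitrogen. In this assay compound 2 gives < 50000 nM, again a limit of the assay. The step that the two limits leave unreadable from compound 1 to compound 2 therefore cannot be read, since both ends of it sit at a limit.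

Compound 3 `O=C(Cn1c(-c2ccccc2)cc(-c2cccc3ccccc23)c1-c1ccco1)Nc1nc2ccccc2s1` is built from the same atoms as compound 1, joined differently; the difference between the two cores is not broken down here. In this assay compound 3 gives < 50000 nM, which is a limit and not a number. Taken together, the limit of < 50000 nM in this assay, at which 3 of the 3 values shown sit, is the only thing the three measurements show.

Compound 4 `CCc1nnc(NC(=O)Cn2c(-c3ccccc3)cc(-c3cccc4ccccc34)c2-c2ccco2)s1` has not been measured in this assay. It differs from compound 3 by 5-ethyl-1,3,4-thiadiazol-2-yl in place of 1,3-benzothiazol-2-yl on an amide-type nitrogen, the same change as that from compound 1 to compound 2, made at the same place on the amide nitrogen. For compound 4 in this assay a step that the limit leaves unreadable from compound 3 to compound 4 is expected, resting only on the fact that the same change could not be read from compound 1 to compound 2 because the limit of < 50000 nM in this assay, at which 3 of the 3 values shown sit, holds for every value seen. Compound 4 is accordingly estimated at 30000 nM, with a range of 5000 nM to 50000 nM, and most likely it too will be reported only as a limit.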

Compound 4, half-maximal inhibitory concentration: < 50000 nM
Compound 4: a limit, no number; the forecaster's own chance of this, stated with the estimate: 85%; the middle value lies beyond the limit too.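

No new step can be read from compound 3 to compound 4 because both compounds sit at the same limit in this assay: the limit of < 50000 nM in this assay, at which 4 of the 4 values shown sit.

The compounds shown leave open whether 5-ethyl-1,3,4-thiadiazol-2-yl in place of 1,3-benzothiazol-2-yl on the amide-type nitrogen changes the read-out at all, and whether the two differently joined cores differ from each other.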